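The source may hold more compounds than are shown below. What is called first, only, known or untested is meant among the compounds shown, and "the series" means these compounds.

In a functional assay on HCT-116 cells (Homo sapiens) for antiproliferative activity, read by MTT assay, with a stated time of 72 h (a higher number here means a weaker inhibitor, a lower number a stronger inhibitor), compound 1, `C=CC/N=C1\S/C(=C\c2ccc(OC)cc2)C(=O)N1C`, gives 79300 nM, and compound 2, `COc1ccc(/C=C2\S/C(=N\c3ccc(C)c(Cl)c3)N(C)C2=O)cc1`, gives 14100 nM. Compound 3, `COc1ccc(/C=C2\S/C(=N\c3c(C)cccc3C)N(C)C2=O)cc1`, reads > 100000 nM, which is a limit of the assay and not a number. Compound 4, `COc1ccc(/C=C2\S/C(=N\c3ccccc3)N(C)C2=O)cc1`, is still unmeasured and carries phenyl in place of 2,6-dimethylphenyl on a double-bonded nitrogen. The measured steps change the group at this same place. They show a 5.6-fold lower number from compound 1 to compound 2 (0.75 log units; beyond the scatter), then an at least 7.0-fold higher number from compound 2 to compound 3 (0.85 log units; beyond the scatter), and also an at least 1.2-fold higher number from compound 1 to compound 3 (0.10 log units; that floor lies within the scatter). Given the step to compound 3 from compound 2, an at least 7.0-fold higher number from compound 2 to compound 3 (0.85 log units; beyond the scatter), a modest move to a lower number is expected in this assay. The expected step is an at least 2.5-fold lower number from compound 3 to compound 4 (0.39 log units; beyond the scatter). The estimate for compound 4 is 40000 nM, with an expected range of 12000 nM to 100000 nM.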

Compound 4, half-maximal inhibitory concentration: > 100000 nM
Compound 4 gave a limit, no number; the forecaster's own chance of this, stated with the estimate: 20%; middle value at least 2.5-fold (0.39 log units) away from the limit.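

In this assay compound 4 reads > 100000 nM, a limit of the assay and not a number. Removing the two methyl groups of 2,6-dimethylphenyl thus gives no readable gain, and plain phenyl falls short of 3-chloro-4-methylphenyl, with an at least 7.0-fold higher number from compound 2 to compound 4 (0.85 log units; beyond the scatter), while against allyl there is an at least 1.2-fold higher number from compound 1 to compound 4 (0.10 log units; that floor lies within the scatter). The step from compound 3 to compound 4 cannot be read, because both compounds end at the same limit: the limit of > 100000 nM in this assay, at which 2 of the 4 values shown sit.

Going by these compounds, whether a chlorophenyl or a methylphenyl alone would match compound 2 stays open. So does what a benzyl group or a longer chain would give on this double-bonded nitrogen.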